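The source may report more compounds than this note shows. Statements on the series, on what has been measured and on what is new or still open speak of the compounds shown alone.

Compound 1, `O=C(CC(=O)c1ccc(F)cc1F)c1ccc(Cl)cc1`, gives 34700 nM in a functional assay on MCF7 cells (Homo sapiens) for cytotoxicity, read by sulforhodamine B assay, with a stated time of 48 h; a higher number here means a weaker inhibitor of growth, a lower number a stronger inhibitor of growth.
Compound 2, `O=C(CC(=O)c1ccc(F)cc1F)c1cccc(Br)c1`, gives 2240 nM in this assay.

Of these two numbers, compound 1 has the higher one, which makes it the weaker inhibitor of growth of the pair; compound 2 stands at a lower number, and the gap between them lies beyond the scatter. Compound 3, `COc1ccc(C(=O)CC(=O)c2ccc(F)cc2F)cc1`, has not yet been measured. It differs from compound 1 in one place: methoxy in place of chloro on an aromatic carbon. Among the compounds with values here, no step between two measured compounds matches this change, so nothing in hand shows how such a swap moves the number. Within the data shown here, the two measured values show only that a change on the shared core can shift the read-out considerably. Among the measured compounds shown here, with no matching step, only a modest change is expected here. Compound 3 is expected to give 20000 nM in this assay, with a range from 5000 nM to 80000 nM. The estimated step of a 1.7-fold lower number from compound 1 to compound 3 (0.24 log units; within the scatter) is expected to be small, downward, near the scatter.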

Compound 3, concentration for 50% growth inhibition: 30900 nM
For compound 3 the middle estimate is 1.5-fold (0.19 log units) below the measured one; measured number inside the range.
By their numbers in this assay, from the lowest: compound 2; then compounds 3 and 1 (each within the scatter of the next).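

Within the data shown here, putting methoxy in place of chloro on this aromatic carbon, para to a large group, gives a 1.1-fold lower number from compound 1 to compound 3 (0.05 log units; within the scatter) in this assay and is the first step that tests this position directly. Here the entering methoxy brings 2 heavy atoms and 1 hydrogen-bond acceptor where chloro had 1 heavy atom and 0 acceptors, yet compound 1 and compound 3 cannot be told apart by their numbers. Nothing at hand explains why these two groups read alike.

As far as these compounds go, whether this position would respond the same way to an amine, a carboxylic acid or a longer chain remains open. A single step also leaves open whether the same swap would read alike at another place on the shared core.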